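Acid to Amide in a Phenoxybenzylamine Agonist Series

A few compounds are considered here, and "the series" means these few. Any claim that something is new, unique, unknown or untested is made for them only; others in the source may bear on it.

Measured compounds:
compound 1, `O=C(O)/C=C/c1ccc(NCc2cccc(Oc3ccccc3)c2)cc1`, 76%
compound 2, `O=C(O)[C@H]1C[C@@H]1c1ccc(NCc2cccc(Oc3ccccc3)c2)cc1`, 88%; 72% (2 entries)
compound 3, `CC(Cc1ccc(NCc2cccc(Oc3ccccc3)c2)cc1)C(=O)O`, 70%

Three compounds share the same core and differ only in the acid-bearing chain. In a functional assay on CHO cells for agonist activity at Free fatty acid receptor 1 (Homo sapiens), read by a luciferase reporter (a higher number here means a larger maximal response, a lower number a smaller maximal response), compound 1 gives 76%, compound 2 gives 88%; 72% (2 entries), and compound 3 gives 70%. Compound 3 stands at the lowest of the two single numbers, with compound 1 nearest; the step of a number 6 percentage points lower from compound 1 to compound 3 (within the scatter) lies within the scatter, so no order between them can be claimed. The repeated entries of compound 2, (the several entries of compound 2 in this assay, 88%; 72% (2 entries)), show how far two measurements of the same compound can drift.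

Compound 4, `NC(=O)CCc1ccc(NCc2cccc(Oc3ccccc3)c2)cc1`, has not yet been measured. It differs from compound 3 by carbamoylmethyl in place of 1-carboxyethyl on a saturated chain carbon bound to an aromatic carbon. Going by the values given here, none of the measured steps touches this group: every measured compound carries a free acid, and the only measured step exchanges one acid-bearing chain for another without moving beyond the scatter. Among the compounds with values here, there is therefore no measured step that bears directly on the change to compound 4, and the expectation must rest on the narrow spread of the measured numbers alone.

Compound 4 is expected to give 50%, within 15% to 85%, in this assay. Within the data shown here, the step of a number 20 percentage points lower from compound 3 to compound 4 (beyond the scatter) is estimated to fall below the measured numbers, but the range is wide since no measured compound lacks the acid.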

Compound 4, largest response reached (reported as percent of maximum), in percent of the reference or control that the assay uses: 68%
Compound 4: middle estimate off by 18 percentage points, on the low side; the measured number falls inside the stated range.
By their numbers in this assay, from the lowest: compounds 4, 3 and 1 (each within the scatter of the next).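

In this assay, a free acid on this chain proves not to be needed for the maximal response: exchanging 1-carboxyethyl for carbamoylmethyl, on a saturated chain carbon bound to an aromatic carbon, gives a number 2 percentage points lower from compound 3 to compound 4 (within the scatter). The comparison with the 2-carboxyethenyl chain reads the same way, with a number 8 percentage points lower from compound 1 to compound 4 (within the scatter), so compound 4, the only compound shown without a carboxylic acid, cannot be told apart from either acid in this assay. Both steps have to be read against the drift between repeated measurements of a single compound: the several entries of compound 2 in this assay, 88%; 72% (2 entries)

The largest response reached says nothing about the concentration needed to reach it, so the compounds shown leave open whether the primary amide and the acids are equally potent. From the compounds shown here alone, it also remains open whether a methyl ester, a nitrile, a tetrazole or a longer chain ending in the same amide would hold the response at this position, or whether the response depends on the hydrogens of the amide nitrogen.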